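Series notes: the step from compound 3 to compound 4

This account rests on a few compounds, and the source may have more. Where it says the series, first, only, none or still open, it means among the compounds named here.

Measured in a functional assay on DU-145 cells (Homo sapiens) for cytotoxicity, read by trypan blue exclusion, with a stated time of 96 h; on this read-out lower numbers stand for stronger inhibition and higher numbers for weaker inhibition:
Compound 1 `COc1cc(OC)c(/C=C/S(=O)(=O)Nc2ccc(OC)c(O)c2)c(OC)c1`: 30 nM
Compound 2 `COC(=O)C(Nc1cc(NS(=O)(=O)/C=C/c2c(OC)cc(OC)cc2OC)ccc1OC)c1ccc(F)cc1`: 2500 nM
Compound 3 `COC(=O)C(Nc1cc(NS(=O)(=O)/C=C/c2c(OC)cc(OC)cc2OC)ccc1OC)c1ccc(Br)cc1`: 7500 nM

Compound 3 has the highest number of the three at 7500 nM, with compound 2 nearest and compound 1 furthest. Compound 4 `COc1cc(OC)c(/C=C/S(=O)(=O)Nc2ccc(OC)c(NC(C(=O)O)c3ccc(F)cc3)c2)c(OC)c1` differs from compound 3 by carboxy(4-fluorophenyl)methyl in place of (4-bromophenyl)(methoxycarbonyl)methyl on a nitrogen on an aromatic ring. Going by the values given here, the only measured step bearing on this is a 3.0-fold higher number from compound 2 to compound 3 (0.48 log units; beyond the scatter), a modest step beyond the scatter, which here would run in reverse for the bromo and fluoro exchange. Among the compounds with values here, no measured step covers carboxy against methoxycarbonyl, so that part remains open. A modest move to a lower number is therefore expected in this assay. The expected change is a 3.8-fold lower number from compound 3 to compound 4 (0.57 log units; beyond the scatter). Compound 4 is estimated at 2000 nM, with an expected range of 300 nM to 10000 nM.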

Compound 4, half-maximal inhibitory concentration: 75 nM
Compound 4: middle estimate off by 27-fold (1.43 log units), on the high side, outside the stated range (below it).
By their numbers in this assay, from the lowest: compound 1; then compound 4; then compound 2; then compound 3.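

Hydrogen in place of methyl on the oxygen next to the carbonyl group accounts for most of the gain at this position, giving a 33-fold lower number from compound 2 to compound 4 (1.52 log units; beyond the scatter) as a large step, whereas bromo against fluoro gave only a 3.0-fold higher number from compound 2 to compound 3 (0.48 log units; beyond the scatter) here. The full exchange of the nitrogen substituent gives a 100-fold lower number from compound 3 to compound 4 (2.00 log units; beyond the scatter) and so depends on the free carboxy group far more than on the halogen. Carboxy(4-fluorophenyl)methylamino in place of hydroxy costs only a modest step, a 2.5-fold higher number from compound 1 to compound 4 (0.40 log units; beyond the scatter) in size, though it remains beyond the scatter. No measured evidence accounts for these steps.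

As far as these compounds go, whether a primary amide or a tetrazole in place of the carboxy group keeps this level stays open. So does the effect of bromo in place of fluoro on the carboxylic acid.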